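Shifting one methyl on the sulfonyl aryl ring

The source may report more compounds than this note shows. Statements on the series, on what has been measured and on what is new or still open speak of the compounds shown alone.

Three compounds have been measured in a functional assay on 143B cells (Homo sapiens) for antiproliferative activity, read by MTT assay, with a stated time of 48 h; a higher number here means a weaker inhibitor, a lower number a stronger inhibitor:

Compound 1 `O=C(/C=C/c1cccc(NS(=O)(=O)c2ccccc2Cl)c1)c1nc2ccccc2[nH]1` — 4790 nM
Compound 2 `O=C(/C=C/c1cccc(NS(=O)(=O)c2cc(Cl)cc(Cl)c2)c1)c1nc2ccccc2[nH]1` — 5950 nM
Compound 3 `Cc1cc(C)cc(S(=O)(=O)Nc2cccc(/C=C/C(=O)c3nc4ccccc4[nH]3)c2)c1` — 3330 nM

Compound 3 has the smallest of these three numbers, yet its steps to compound 1 and compound 2 both lie within the scatter, so none of the three stands apart. Compound 4 `Cc1ccc(S(=O)(=O)Nc2cccc(/C=C/C(=O)c3nc4ccccc4[nH]3)c2)cc1C` differs from compound 3 by 3,4-dimethylphenyl in place of 3,5-dimethylphenyl on a sulfonyl sulfur. All three measured steps change this same ring: a 1.2-fold higher number from compound 1 to compound 2 (0.09 log units; within the scatter), a 1.4-fold lower number from compound 1 to compound 3 (0.16 log units; within the scatter) and a 1.8-fold lower number from compound 2 to compound 3 (0.25 log units; within the scatter). None went beyond the scatter. Moving one methyl on that ring is therefore expected to give at most a small step, a 1.1-fold higher number from compound 3 to compound 4 (0.03 log units; within the scatter), in no clear direction. Compound 4 is estimated at 3600 nM, with a range from 1800 nM to 7200 nM.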

Compound 4, half-maximal inhibitory concentration: 5050 nM
For compound 4 the middle estimate is 1.4-fold (0.15 log units) below the measured one, and the stated range covers the measured number.
By their numbers in this assay, from the lowest: compounds 3, 1, 4 and 2 (each within the scatter of the next).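

In this assay moving one methyl on the ring on the sulfonyl sulfur gives a 1.5-fold higher number from compound 3 to compound 4 (0.18 log units; within the scatter) and so leaves the reading within the scatter, even though the two compounds have the same atoms, joined differently. The other new steps, a 1.2-fold lower number from compound 2 to compound 4 (0.07 log units; within the scatter) and a 1.1-fold higher number from compound 1 to compound 4 (0.02 log units; within the scatter) also lie within the scatter, so all four rings at this place read alike. No evidence is available that would explain this result.

Still open, as far as these compounds go, is whether a ring carrying an amine or a carboxylic acid, or a longer chain such as butyl in place of a methyl, would give a step beyond the scatter.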